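A few compounds are considered here, and "the series" means these few. Any claim that something is new, unique, unknown or untested is made for them only; others in the source may bear on it.

Of the compounds shown here, three have so far been tested in a functional assay on SW480 cells (Homo sapiens) for cytotoxicity, read by MTT assay, with a stated time of 4 days; on this read-out lower numbers stand for stronger inhibition and higher numbers for weaker inhibition. Compound 1 `C=C1C[C@]23C[C@@]1(O)CC[C@H]2c1ccc(OS(=O)(=O)c2ccc(C)cc2)c(C)c1[C@@H]3Cn1cc(-c2ccc(Cl)cc2)nn1` sits at > 20000 nM in this assay, which is a limit rather than a number. Compound 3 `C=C1C[C@]23C[C@@]1(O)CC[C@H]2c1ccc(O)c(C)c1[C@@H]3Cn1cc(-c2ccc(Br)cc2)nn1` likewise sits at > 20000 nM in this assay, again a limit. Among the compounds with values here, compound 2 `C=C1C(=O)[C@]23C[C@@]1(O)CC[C@H]2c1ccc(OS(=O)(=O)c2ccc(C)cc2)c(C)c1[C@@H]3Cn1cc(-c2ccc(Br)cc2)nn1` gives 1590 nM in this assay and is thus the only compound with a numerical value. Two of the three values shown share (the limit of > 20000 nM in this assay, at which 2 of the 3 values shown sit). Within the data shown here, no pair of measured compounds differs in a single place, so no measured step is available. Compound 4 `C=C1C(=O)[C@]23C[C@@]1(O)CC[C@H]2c1ccc(OS(=O)(=O)c2ccc(C)cc2)c(C)c1[C@@H]3Cn1cc(-c2ccc(C)cc2)nn1` differs from compound 2 by methyl in place of bromo on an aromatic carbon. No shift beyond the usual scatter is expected in this assay in either direction. The expected step is a 1.6-fold higher number from compound 2 to compound 4 (0.20 log units; within the scatter). Compound 4 is therefore estimated to give 2500 nM in this assay, with a range from 800 nM to 8000 nM.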

Compound 4, half-maximal inhibitory concentration: 1460 nM
Compound 4: the middle estimate sits 1.7-fold (0.23 log units) above what was measured, within the range that was stated.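

Within the data shown here, the 4-bromophenyl to 4-methylphenyl exchange, on an aromatic carbon para to a large group, gives the first readable step in this assay: a 1.1-fold lower number from compound 2 to compound 4 (0.04 log units; within the scatter). The numerical value of compound 2 therefore does not depend on bromo specifically, as methyl serves equally at this position. No measured property shown accounts for this flat step.

Going by these compounds, whether an amine or a carboxylic acid at this position would also leave the value unchanged remains open. Compound 1 and compound 3 each differ from compound 2 in more than one place, so the feature separating their limits from its value stays unresolved.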